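A few compounds are considered here, and "the series" means these few. Any claim that something is new, unique, unknown or untested is made for them only; others in the source may bear on it.

Working notes on the series.

Three compounds share the core of compound 1 `CC(C)N(CCN(C(=O)Nc1cccc(Br)c1)C1CC[C@]2(c3cccc(C#N)c3)CC2C1)C(C)C` and have been measured in a functional assay for antagonist activity at melanin-concentrating hormone receptor 1 (Homo sapiens); on this read-out higher numbers stand for weaker inhibition and lower numbers for stronger inhibition. Compound 1 gives 5.7 nM. Compound 3 `CC(C)N(CCN(C(=O)Nc1cc(Cl)nc(Cl)c1)C1CC[C@]2(c3cccc(C#N)c3)CC2C1)C(C)C` gives 2.4 nM, and the change from compound 1 to compound 3, 2,6-dichloropyridin-4-yl in place of 3-bromophenyl on an amide-type nitrogen, brings a 2.4-fold lower number from compound 1 to compound 3 (0.38 log units; beyond the scatter). Compound 2 `N#Cc1cccc([C@]23CCC(N(CCN4CCCC(O)C4)C(=O)Nc4ccc(F)c(Cl)c4)CC2C3)c1` gives 22 nM, the highest number of the three, with compound 1 nearest and compound 3 furthest from it. For the measured compounds named here, compound 2 differs from both in more than one place, so no single step is defined for it.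

Compound 4 `CS(=O)(=O)N1CCC(CN(C(=O)Nc2ccc(F)c(Cl)c2)C2CC[C@]3(c4cccc(C#N)c4)CC3C2)CC1` is not yet measured. It differs from compound 2 by 1-(methylsulfonyl)piperidin-4-yl in place of (3-hydroxypiperidin-1-yl)methyl on a saturated chain carbon bound to an amide-type nitrogen. Going by the values given here, none of the measured steps touches this part of the molecule; the only defined step concerns the aryl urea end. There is therefore no measured basis for a direction. With compound 2 at 22 nM as the only anchor, a number within the scatter of it is expected for compound 4, 18 nM, from 5 nM to 70 nM. The expected step is a 1.2-fold lower number from compound 2 to compound 4 (0.09 log units; within the scatter).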

Compound 4, inhibition constant: 7.19 nM
Compound 4: the middle estimate sits 2.5-fold (0.40 log units) above what was measured, and the stated range covers the measured number.
By their numbers in this assay, from the lowest: compound 3; then compounds 1 and 4 (each within the scatter of the next); then compound 2.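

In this assay this position, on a saturated chain carbon bound to an amide-type nitrogen, is sensitive to the group it carries: 1-(methylsulfonyl)piperidin-4-yl in place of (3-hydroxypiperidin-1-yl)methyl gives a 3.1-fold lower number from compound 2 to compound 4 (0.49 log units; beyond the scatter) with the aryl end unchanged. For the compounds shown here, the earlier step touched only the aryl end, so this is the only reading on this part of the molecule; the change loses the hydrogen-bond donor and adds the sulfur, but one step cannot separate these features. Nothing measured here accounts for the shift.

As far as these compounds go, it remains open whether a 1-acetylpiperidin-4-yl group or a plain piperidin-4-yl amine would give a similar number at this position. Also open, from the compounds shown here alone, is whether the same change would carry over with 2,6-dichloropyridin-4-yl on the amide-type nitrogen.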